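Furan in place of phenyl on the shared core

The source may hold more compounds than are shown below. What is called first, only, known or untested is meant among the compounds shown, and "the series" means these compounds.

Measured so far:
- compound 1 `Nc1nc(-c2ccccc2)nc2sc(-c3ccccc3)nc12`: 84 nM
- compound 2 `Nc1nc(-c2cccc(CO)c2)nc2sc(-c3ccccc3)nc12`: 3.7 nM
- compound 3 `COc1cccc(-c2nc(N)c3nc(-c4ccccc4)sc3n2)c1`: 35.6 nM

These three compounds were tested in an assay on CHO cells for displacement of a labelled ligand from adenosine receptor A3 (Homo sapiens), read by scintillation counting, with a stated time of 3 h; a lower number here means a stronger inhibitor, a higher number a weaker inhibitor. Compound 2 gives the lowest number of the three: the step of a 23-fold lower number from compound 1 to compound 2 (1.36 log units; beyond the scatter) was large, and the step of a 9.6-fold higher number from compound 2 to compound 3 (0.98 log units; beyond the scatter) was modest, so compound 2 is the strongest of the measured set.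

Compound 4 `Nc1nc(-c2cccc(CO)c2)nc2sc(-c3ccco3)nc12` keeps the hydroxymethyl of compound 2 and changes the other ring: furan-2-yl in place of phenyl on an aromatic carbon. Among the compounds with values here, none of the measured steps touches this ring; they all concern the hydroxymethyl or methoxy on the first phenyl. Within the data shown here, no measured step therefore bears directly on this change, and the expectation rests only on compound 2 keeping its hydroxymethyl. The step of a 1.4-fold higher number from compound 2 to compound 4 (0.13 log units; within the scatter) is expected to stay within the scatter, and compound 4 is estimated at 5 nM in this assay, within 1.5 nM to 18 nM.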

Compound 4, inhibition constant: 0.9 nM
The estimate for compound 4 lay 5.6-fold (0.74 log units) above the measured number; the whole stated range lies above it.
By their numbers in this assay, from the lowest: compound 4; then compound 2; then compound 3; then compound 1.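

Until now, every step concerned substituents on the other phenyl. This result shows that the group on the aromatic carbon next to the ring nitrogen and the ring sulfur also moves the number: furan-2-yl in place of phenyl gives a 4.1-fold lower number from compound 2 to compound 4 (0.61 log units; beyond the scatter) and adds one hydrogen-bond acceptor to the count. Nothing available explains this gain.

Furan-2-yl appears only alongside the hydroxymethyl, so whether the gain also holds with methoxy or hydrogen there remains open. Going by these compounds, how an amine or a longer chain would fare at this carbon also remains open.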